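Heteroaryl swaps on the sulfonamide nitrogen: estimate for compound 4

This account rests on a few compounds, and the source may have more. Where it says the series, first, only, none or still open, it means among the compounds named here.

Measured so far in a functional assay on HCT-15 cells (Homo sapiens) for inhibition, read by sulforhodamine B assay, with a stated time of 48 h; on this read-out higher numbers stand for weaker inhibition of growth and lower numbers for stronger inhibition of growth:
- compound 1, `C=C1CC[C@@H]2[C@](C)(COC(C)=O)[C@H](OC(C)=O)CC[C@@]2(C)[C@H]1CC(Nc1ccc(S(=O)(=O)Nc2nccs2)cc1)C1=CCOC1=O`, 1730 nM
- compound 2, `C=C1CC[C@@H]2[C@](C)(COC(C)=O)[C@H](OC(C)=O)CC[C@@]2(C)[C@H]1CC(Nc1ccc(S(=O)(=O)Nc2ccc(Cl)nn2)cc1)C1=CCOC1=O`, 880 nM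
- compound 3, `C=C1CC[C@@H]2[C@](C)(COC(C)=O)[C@H](OC(C)=O)CC[C@@]2(C)[C@H]1CC(Nc1ccc(S(=O)(=O)Nc2ncccn2)cc1)C1=CCOC1=O`, 1210 nM

Compound 2 carries the lowest of the three numbers, but neither of its gaps to the others leaves the scatter: a 2.0-fold lower number from compound 1 to compound 2 (0.29 log units; within the scatter), and a 1.4-fold higher number from compound 2 to compound 3 (0.14 log units; within the scatter). The remaining pair behaves the same way, a 1.4-fold lower number from compound 1 to compound 3 (0.16 log units; within the scatter). Across the three measured compounds the group on the sulfonamide nitrogen has therefore not moved the read-out beyond the usual spread of repeats.

Going by the values given here, the next step keeps the shared core of compound 2 and again changes only that group. Compound 4, `C=C1CC[C@@H]2[C@](C)(COC(C)=O)[C@H](OC(C)=O)CC[C@@]2(C)[C@H]1CC(Nc1ccc(S(=O)(=O)Nc2cc(C)on2)cc1)C1=CCOC1=O`, differs from compound 2 by 5-methyl-1,2-oxazol-3-yl in place of 6-chloropyridazin-3-yl on a sulfonamide nitrogen.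

All three measured steps bear on this change, since each is a heteroaryl exchange at the same sulfonamide nitrogen, and each stayed within the scatter. No step beyond the scatter is therefore expected in this assay, in either direction; the estimate is placed a little above compound 2, nearer the middle of the three measured numbers, with a range wide enough to cover them all. For compound 4 the expected value is 1200 nM, with a range from 500 nM to 3000 nM. The corresponding expected step is a 1.4-fold higher number from compound 2 to compound 4 (0.13 log units; within the scatter).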

Compound 4, concentration for 50% growth inhibition: 1500 nM
The estimate for compound 4 lay 1.3-fold (0.10 log units) below the measured number; the range from low to high includes it.
By their numbers in this assay, from the lowest: compounds 2, 3, 4 and 1 (each within the scatter of the next).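

In this assay, the exchange of 6-chloropyridazin-3-yl for 5-methyl-1,2-oxazol-3-yl gives a 1.7-fold higher number from compound 2 to compound 4 (0.23 log units; within the scatter) and stays as small as the exchanges from the other two measured groups, which give a 1.2-fold higher number from compound 3 to compound 4 (0.09 log units; within the scatter) and a 1.2-fold lower number from compound 1 to compound 4 (0.06 log units; within the scatter) in turn. Compound 4 brings the first ring in the set with an oxygen and the first with a methyl group, and neither addition takes the read-out outside the scatter of the other three compounds, so all four heteroaryl groups on the sulfonamide nitrogen remain indistinguishable in this read-out. Nothing available accounts for this flat response at the position.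

The four groups shown are all aromatic rings with hetero atoms, so it remains open whether a plain phenyl ring, a simple acetyl group or a bare hydrogen on the sulfonamide nitrogen would give a step beyond the scatter. From the compounds shown here alone, it is also open whether this insensitivity would persist if the acetate esters on the shared core were replaced by free hydroxyl groups.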